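Cyclohexyl ester expected to recover inhibition lost by thioester

This account rests on a few compounds, and the source may have more. Where it says the series, first, only, none or still open, it means among the compounds named here.

Three compounds share one core and differ only in the group on the carbonyl carbon. Compound 1 `CC1=C(C(=O)OCc2ccccc2)C(c2cccs2)NC(=O)N1` gives 45% in an assay on membranes from CHO cells for displacement of a labelled ligand from adenosine receptor A1 (Homo sapiens), read by scintillation counting, with a stated time of 60 min, tested at 1 uM; a higher number here means more inhibition at the concentration tested (going by the name of the read-out), a lower number less inhibition. Compound 2 `CC1=C(C(=O)C2CC2)C(c2cccs2)NC(=O)N1` gives 1% in this assay, and compound 3 `CCSC(=O)C1=C(C)NC(=O)NC1c1cccs1` gives 6%, a step of a number 5 percentage points higher from compound 2 to compound 3 (within the scatter). Compound 3 thus stands second highest of the three, close to compound 2 and far below compound 1. Compound 4 `CC1=C(C(=O)OC2CCCCC2)C(c2cccs2)NC(=O)N1` differs from compound 3 by cyclohexyloxy in place of ethylsulfanyl on a carbonyl carbon. For the measured compounds named here, no measured step alters an ester or thioester group directly; the only measured step lies within the scatter, while compound 1, the other ester, sits well above compound 3. Compound 4 is therefore expected to rise, by an estimated step of a number 24 percentage points higher from compound 3 to compound 4 (beyond the scatter). The estimate for compound 4 is 30%, between 5% and 60%.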

Compound 4, a percentage reported as inhibition, at one concentration (the size of the read-out at that concentration, not a potency): 7%
Compound 4: the middle estimate sits 23 percentage points above what was measured; the measured number falls inside the stated range.
By their numbers in this assay, from the lowest: compounds 2, 3 and 4 (each within the scatter of the next); then compound 1.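

In this assay, having an ester on the carbonyl carbon does not by itself set the inhibition apart: the data show a number 1 percentage points higher from compound 3 to compound 4 (within the scatter) and a number 6 percentage points higher from compound 2 to compound 4 (within the scatter), so cyclohexyloxy cannot be told from ethylsulfanyl or cyclopropyl here. The group on the ester oxygen does matter, since the data show a number 38 percentage points lower from compound 1 to compound 4 (beyond the scatter) with cyclohexyl in place of benzyl. Nothing available accounts for this gap between the two esters. On these data alone, whether a methyl ester, a phenethyl ester or an amine-derived amide on that carbonyl carbon would fall with compound 1 or with compound 4 remains open.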